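A few compounds are considered here, and "the series" means these few. Any claim that something is new, unique, unknown or untested is made for them only; others in the source may bear on it.

Going by the values given here, compound 3 `Cn1cc(C2=C(c3nn(CCCO)c4ncccc34)C(=O)NC2=O)c2ccccc21` gives, in a functional assay on K562 cells (Homo sapiens) for antiproliferative activity, read by MTT assay, with a stated time of 48 h (on this read-out higher numbers stand for weaker inhibition and lower numbers for stronger inhibition), 85800 nM; of the three values shown it is the only one that is a number. Compound 1 `Cn1cc(C2=C(c3nn(CCn4ccnc4)c4ncccc34)C(=O)NC2=O)c2ccccc21` gives only a limit in this assay, > 100000 nM. Compound 2 `Cn1cc(C2=C(c3nn(CCCN4CCCCC4)c4ncccc34)C(=O)N(c3ccccn3)C2=O)c2ccccc21` likewise gives only a limit in this assay, > 100000 nM. Among the compounds with values here, the one measured step that is a single change is an at least 1.1-fold lower number from compound 1 to compound 3 (0.06 log units; that floor lies within the scatter), and it lies within the scatter. Compound 4 `Cn1cc(C2=C(c3nn(CCCn4cncn4)c4ncccc34)C(=O)NC2=O)c2ccccc21` differs from compound 3 by 1H-1,2,4-triazol-1-yl in place of hydroxy on a saturated chain carbon, three bonds along the chain from an aromatic nitrogen. This change bears a likeness to the step from compound 1 to compound 3 taken backwards, an azole entering where a hydroxy group leaves, though cut one bond further out; that step was within the scatter, and the limit of > 100000 nM in this assay, at which 2 of the 3 values shown sit, is where two of the three values shown sit. Compound 4 is therefore expected to show no step beyond the scatter, a 1.4-fold higher number from compound 3 to compound 4 (0.15 log units; within the scatter), with a fair chance that this assay reports only a limit. Compound 4 is estimated at 120000 nM, between 50000 nM and 300000 nM.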

Compound 4, half-maximal inhibitory concentration: > 100000 nM
Compound 4 gave a limit, no number; the forecaster's own chance of this, stated with the estimate: 60%; the middle value is on the limit's open side.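

On the 3-hydroxypropyl chain, three bonds along from an aromatic nitrogen, the swap of hydroxy for 1H-1,2,4-triazol-1-yl gives an at least 1.1-fold higher number from compound 3 to compound 4 (0.06 log units; that floor lies within the scatter), so in this assay this change shows no step beyond the scatter, though its true size stays hidden behind a limit. The step from compound 1 to compound 4 joins two limits and cannot be read. With compound 4, whose value is a limit and not a number, a second azole-bearing chain now ends at the same limit, and compound 3 remains the only one with a number: the limit of > 100000 nM in this assay, at which 3 of the 4 values shown sit.

As far as these compounds go, whether any chain end moves this series clear of the scatter remains open. A primary amine or a carboxylic acid in place of hydroxy on the same chain, or a longer chain still ending in hydroxy, would test this.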